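The compounds below may be only part of what the source reports. "The series", "measured", "known", "first", "only" and "open" are said of these compounds alone.

In an ADME assay on L929 cells (Mus musculus) for cytotoxicity, read by resazurin assay, with a stated time of 48 h (on this read-out lower numbers stand for higher toxicity in this test and higher numbers for lower toxicity in this test), three compounds built on one shared core have been measured. Compound 1 `C=CCn1c2ccc([N+](=O)[O-])cc2c(=O)n1Cc1ccccc1` gives a true number, 192000 nM. Compound 2 `O=C(O)CCCn1c2ccc([N+](=O)[O-])cc2c(=O)n1Cc1ccccc1` reports only a limit, > 256000 nM. As far as these compounds go, compound 3 `O=c1c2cc([N+](=O)[O-])ccc2n(CCCO)n1Cc1ccccc1` also reports only a limit, > 256000 nM, so its real number is unknown. It stands at the limit of > 256000 nM in this assay, at which 2 of the 3 values shown sit.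

Compound 4 `COCCn1c2ccc([N+](=O)[O-])cc2c(=O)n1Cc1ccccc1` differs from compound 3 in one place: methoxy in place of hydroxymethyl on a saturated chain carbon, two bonds along the chain from an aromatic nitrogen. The two have the same atoms, joined differently.

Among the measured compounds shown here, no measured step makes this exact change, but three steps alter the same chain. They are an at least 1.3-fold higher number from compound 1 to compound 3 (0.12 log units; that floor lies within the scatter), an at least 1.3-fold higher number from compound 1 to compound 2 (0.12 log units; that floor lies within the scatter) and a step that the two limits leave unreadable from compound 2 to compound 3. None of them shows a change beyond the scatter, so no step beyond the scatter is expected in this assay here. The estimated step is an at least 1.1-fold lower number from compound 3 to compound 4 (0.04 log units; that floor lies within the scatter), and it is expected to be small. For the measured compounds named here, the only true number comes from compound 1 at 192000 nM, which anchors the expectation. For compound 4 the estimated value is 230000 nM, with an expected range from 120000 nM to 400000 nM.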

Compound 4, concentration lethal to 50% of the cells: > 256000 nM
Compound 4: only a limit was reported; the forecaster's own chance of this, stated with the estimate: 45%; at least 1.1-fold (0.04 log units) between middle value and limit.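

In this assay compound 4 reports only a limit, > 256000 nM. Replacing 3-hydroxypropyl with 2-methoxyethyl removes the hydrogen-bond donor of the leaving hydroxymethyl while keeping the same atoms, yet this compound, like compound 3, still gives no true number, and the steps from compound 3 and from compound 2 to compound 4 cannot be read, since both ends of each are limits. The one readable step is an at least 1.3-fold higher number from compound 1 to compound 4 (0.12 log units; that floor lies within the scatter), so it gives only a floor against the single true number in the series, and an ether chain now joins the acid and the alcohol in sitting at the limit: the limit of > 256000 nM in this assay, at which 3 of the 4 values shown sit.

As far as these compounds go, how far compound 2, compound 3 and compound 4 really lie past that limit stays unknown, so no order among them can be given. Among the compounds shown here, it also remains open whether a chain ending in an amine, or a longer chain ending in a methoxy group, would stay at the limit or give a true number like the one from compound 1.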